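Carbamoyl gives way to ethyl in a cytotoxicity series

The compounds below may be only part of what the source reports. "The series", "measured", "known", "first", "only" and "open" are said of these compounds alone.

Compound 1 `FC(F)(F)Oc1ccc(Nc2ncnc3c2cnn3CC2CCOC2)cc1`: in an ADME assay on BaF3 cells (Mus musculus) for cytotoxicity (on this read-out higher numbers stand for an effect only at larger amounts of compound and lower numbers for an effect already at smaller amounts), compound 1 gives > 10000 nM, which is a limit of the assay rather than a number.
Compound 2 `NC(=O)Cn1ncc2c(Nc3ccc(OC(F)(F)F)cc3)ncnc21`: compound 2 gives 3300 nM.

Within the data shown here, compound 2 thus holds the only number in this set; the other value sits at the limit of > 10000 nM in this assay, at which 1 of the 2 values shown sits. Compound 3 `CCCn1ncc2c(Nc3ccc(OC(F)(F)F)cc3)ncnc21` differs from compound 2 by ethyl in place of carbamoyl on a saturated chain carbon bound to an aromatic nitrogen. Among the measured compounds shown here, the one measured step bearing on this, an at least 3.0-fold lower number from compound 1 to compound 2 (0.48 log units; beyond the scatter), ran toward a lower number when carbamoyl entered; the change to compound 3 removes carbamoyl again, so a step back toward a higher number is expected, a 2.1-fold higher number from compound 2 to compound 3 (0.33 log units; beyond the scatter). Compound 3 is estimated at 7000 nM, with a range from 3000 nM to 16000 nM.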

Compound 3, half-maximal effective concentration: 6600 nM
The estimate for compound 3 lay 1.1-fold (0.03 log units) above the measured number; measured number inside the range.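

In this assay, ethyl in place of carbamoyl at this position gives a 2.0-fold higher number from compound 2 to compound 3 (0.30 log units; within the scatter), so the two compounds cannot be told apart on this read-out. Ethyl in place of oxolan-3-yl gives an at least 1.5-fold lower number from compound 1 to compound 3 (0.18 log units; that floor lies within the scatter), so unlike carbamoyl, ethyl shows no step from oxolan-3-yl beyond the scatter. The value of compound 1 remains a limit and not a number: the limit of > 10000 nM in this assay, at which 1 of the 3 values shown sits.

On these data alone, what remains open is whether an amine, a carboxylic acid or a chain longer than propyl at this position would give a number beyond the scatter of those already seen.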